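Dihydropyridine aryl variation in guinea-pig muscle

This account rests on a few compounds, and the source may have more. Where it says the series, first, only, none or still open, it means among the compounds named here.

Of the compounds shown here, three of one core have been measured in a functional assay (muscle tissue) with Cavia porcellus as the target; on this read-out higher numbers stand for an effect only at larger amounts of compound and lower numbers for an effect already at smaller amounts. Compound 1 `COC(=O)C1=C(C)N=C(C)/C(=C(\O)OC)C1c1c(F)c(F)c(F)c(F)c1F` gives 4.37 nM. Compound 2 `COC(=O)C1=C(C)N=C(C)/C(=C(\O)OC)C1c1cc(OC)c(OC)cc1OC` gives 1000000 nM. Compound 3 `COC(=O)C1=C(C)N=C(C)/C(=C(\O)OC)C1c1ccc(F)cc1` gives 129 nM, the second highest of the three numbers: compound 1 lies beyond the scatter below it, and compound 2 lies beyond the scatter above it. Going by the values given here, with only three aryl groups covered, no pattern across them can be claimed.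

Compound 4 `COC(=O)C1=C(C)N=C(C)/C(=C(\O)OC)C1c1cccc(C)c1` is not yet measured. It differs from compound 3 as follows: 3-methylphenyl in place of 4-fluorophenyl on a saturated ring carbon.

In this assay the step from compound 3 to compound 4 is expected to be small, at most a modest move towards a lower number, and may well stay within the scatter, since the only near reference point is compound 3 at 129 nM and nothing in the three measured compounds pins down what a methyl-bearing phenyl does. Compound 4 is therefore estimated at 70 nM, in a range from 15 nM to 400 nM, which implies a step of a 1.8-fold lower number from compound 3 to compound 4 (0.27 log units; within the scatter) for compound 4.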

Compound 4, half-maximal effective concentration: 110 nM
Beside the measured number, compound 4's estimate is 1.6-fold (0.20 log units) below it, and the stated range covers the measured number.
By their numbers in this assay, from the lowest: compound 1; then compounds 4 and 3 (each within the scatter of the next); then compound 2.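

Going by these compounds alone, exchanging 4-fluorophenyl for 3-methylphenyl on the saturated ring carbon gives a 1.2-fold lower number from compound 3 to compound 4 (0.07 log units; within the scatter) in this assay, the first pair that can be read directly, and on this read-out the two aryl groups cannot be told apart. The exchange alters both the substituent and its place on the phenyl ring, so this single step does not allow either change to be judged alone. No available data bear on why the two compounds read alike.

Open, from the compounds shown here alone, is how 4-methylphenyl and 3-fluorophenyl would read on the same core, as these would separate the two changes. Also open, going by these compounds, is what a phenyl ring carrying an amine or a carboxylic acid at either of these two ring places would do in this assay.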